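From tert-butyl to phenyl: an expected affinity for compound 3

This account rests on a few compounds, and the source may have more. Where it says the series, first, only, none or still open, it means among the compounds named here.

Compound 1 `CCOCCC1([C@H](O)/C=C/[C@H]2COC(=O)N2CCSc2nc(C(=O)O)cs2)CCC1`: 8420 nM in an assay on isolated protein for binding affinity to prostaglandin E2 receptor EP1 subtype (Homo sapiens); a lower number here means a stronger inhibitor, a higher number a weaker inhibitor
Compound 2 `CC(C)(C)CCC1([C@H](O)/C=C/[C@H]2COC(=O)N2CCSc2nc(C(=O)O)cs2)CCC1`: 149 nM in this assay

Among the measured compounds shown here, of the two measured compounds, compound 2 has the lowest number; the only measured step, a 57-fold lower number from compound 1 to compound 2 (1.75 log units; beyond the scatter), is large. Compound 3 `O=C(O)c1csc(SCCN2C(=O)OC[C@@H]2/C=C/[C@@H](O)C2(CCc3ccccc3)CCC2)n1` differs from compound 2 in one place: phenyl in place of tert-butyl on a saturated chain carbon, two bonds along the chain from a saturated ring carbon. The measured step concerns a different exchange at the same place, so it bears on this one only by showing that the group there matters strongly. For the measured compounds named here, with no direct precedent, no step beyond the scatter is expected, so compound 3 is estimated at 180 nM, within 40 nM to 800 nM. The expected step is a 1.2-fold higher number from compound 2 to compound 3 (0.08 log units; within the scatter).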

Compound 3, inhibition constant: 802 nM
Estimate against measurement, compound 3: 4.5-fold (0.65 log units) below; measured number outside the range, above it.
By their numbers in this assay, from the lowest: compound 2; then compound 3; then compound 1.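

Phenyl in place of tert-butyl weakens binding (a 5.4-fold higher number from compound 2 to compound 3 (0.73 log units; beyond the scatter)), so these two carbon-only groups are not interchangeable at this place on the chain. Phenyl in place of ethoxy strengthens it (a 10-fold lower number from compound 1 to compound 3 (1.02 log units; beyond the scatter)), which puts phenyl in the middle of the three groups compared here. Nothing available explains this order. The compounds shown leave open how an amine, a carboxylic acid or a longer chain would behave at this place. They also leave open whether a phenyl ring carrying a fluorine or a methoxy group would recover the affinity of compound 2.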